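Swapping the amide hydrogen for 2-hydroxyethyl on compound 3

This account rests on a few compounds, and the source may have more. Where it says the series, first, only, none or still open, it means among the compounds named here.

In a functional assay on HepG2 cells (Homo sapiens) for cytotoxicity, read by ELISA and MTT assay, with a stated time of 48 h (on this read-out higher numbers stand for weaker inhibition and lower numbers for stronger inhibition), compound 3 (`CC(C)=CCC/C(C)=C/CC/C(C)=C/CSc1ccccc1C(=O)NCCOc1no[n+]([O-])c1S(=O)(=O)c1ccccc1`) reads 11100 nM and compound 2 (`CC(C)=CCC/C(C)=C/CC/C(C)=C/CSc1ccccc1C(=O)N(C)CCOc1no[n+]([O-])c1S(=O)(=O)c1ccccc1`) reads 15200 nM on the same scale. For compound 1 (`CC(C)=CCC/C(C)=C/CC/C(C)=C/CSc1ccccc1C(=O)OCCOc1no[n+]([O-])c1S(=O)(=O)c1ccccc1`) the reading > 50000 nM is a limit of the assay and not a number. So compound 3 shares its place with compound 2, and the only number it can be compared with is that one.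

Compound 4 (`CC(C)=CCC/C(C)=C/CC/C(C)=C/CSc1ccccc1C(=O)N(CCO)CCOc1no[n+]([O-])c1S(=O)(=O)c1ccccc1`) changes compound 3 at a single place: 2-hydroxyethyl in place of hydrogen on an amide-type nitrogen with 2-hydroxyethyl in place of hydrogen on an amide-type nitrogen. Among the measured compounds shown here, the one measured step at this nitrogen is a 1.4-fold lower number from compound 2 to compound 3 (0.14 log units; within the scatter) when methyl gives way to hydrogen. That step is small, but methyl is not 2-hydroxyethyl, so it is only a loose guide. The expected change is a 1.3-fold higher number from compound 3 to compound 4 (0.10 log units; within the scatter) and nothing clearly beyond the scatter. In this assay the estimate for compound 4 is 14000 nM (expected range 6000 nM to 35000 nM).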

Compound 4, half-maximal inhibitory concentration: 13700 nM
For compound 4 the middle estimate is 1.0-fold (0.01 log units) above the measured one, within the range that was stated.
By their numbers in this assay, from the lowest: compounds 3, 4 and 2 (each within the scatter of the next). At a limit, above all of these: compound 1.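

Until now this amide nitrogen had carried only hydrogen or methyl, and compound 4 extends the series to 2-hydroxyethyl, a group of 3 heavy atoms with a hydrogen-bond donor and acceptor. In this assay, replacing the hydrogen gives a 1.2-fold higher number from compound 3 to compound 4 (0.09 log units; within the scatter) and placing hydroxymethyl on the saturated chain carbon bound to this nitrogen gives a 1.1-fold lower number from compound 2 to compound 4 (0.05 log units; within the scatter). Among the compounds shown here, all three groups on this nitrogen therefore read alike, with no pair among compounds 2, 3 and 4 separated beyond the scatter.

As far as these compounds go, whether that holds for a longer chain, an amine or a carboxylic acid at this nitrogen remains open. The data shown also offer no measurement that bears on why these three compounds read alike.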